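The source may hold more compounds than are shown below. What is called first, only, known or untested is meant among the compounds shown, and "the series" means these compounds.

Compound 1: `COc1cc(CC(O)c2ccc(-c3ccc(Cl)cc3)cc2)c([N+](=O)[O-])cc1OC` gives 4100 nM in an ADME assay on HeLa Rh cells (Homo sapiens) for cytotoxicity, read by microscopy; a higher number here means that more compound is tolerated, a lower number that less compound is tolerated.
Compound 2: `COc1cc(CC(O)c2ccc(-c3cccnc3)cc2)c([N+](=O)[O-])cc1OC` gives > 263000 nM in this assay.

Compound 2 stands at the top of what this assay can report, and its value of > 263000 nM is a limit of the assay rather than a number, as the limit of > 263000 nM in this assay, at which 1 of the 2 values shown sits, records. Compound 3, `COc1cc(CC(O)c2ccc(-c3ccoc3)cc2)c([N+](=O)[O-])cc1OC`, differs from compound 2 in one place: furan-3-yl in place of pyridin-3-yl on an aromatic carbon. Going by the values given here, the only measured step, an at least 64-fold higher number from compound 1 to compound 2 (1.80 log units; beyond the scatter), changed the group at this same place, and it was large. With compound 2 already at the limit, compound 3 can only stay there or come down from it. The expected step is an at least 2.6-fold lower number from compound 2 to compound 3 (0.41 log units; beyond the scatter), a fall, but with wide uncertainty. Compound 3 is estimated at 100000 nM in this assay. For compound 3 the likely range runs from 20000 nM to 263000 nM, and a limit rather than a number remains quite possible.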

Compound 3, half-maximal cytotoxic concentration: 5300 nM
For compound 3 the middle estimate is 19-fold (1.28 log units) above the measured one, and the stated range ends above it.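

Swapping pyridin-3-yl for furan-3-yl at this position gives an at least 49-fold lower number from compound 2 to compound 3 (1.69 log units; beyond the scatter), so the high tolerance of compound 2 does not carry over to every aromatic ring with one hetero atom placed here. Going by these compounds alone, the furan-3-yl and 4-chlorophenyl groups lie within the scatter of each other in this assay, with a 1.3-fold higher number from compound 1 to compound 3 (0.11 log units; within the scatter), which leaves pyridin-3-yl as the one group of the three that stands apart. As far as these compounds go, the true size of the fall from compound 2 remains unknown because the value of compound 2 is a limit and not a number: the limit of > 263000 nM in this assay, at which 1 of the 3 values shown sits.

From the compounds shown here alone, whether the ring nitrogen of pyridin-3-yl is what sets it apart remains open. A plain phenyl, a pyridin-4-yl or a morpholine at this place could help to answer that question.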